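Bromo for fluoro: working notes on a small series

The source may hold more compounds than are shown below. What is called first, only, known or untested is meant among the compounds shown, and "the series" means these compounds.

- compound 1 `Cc1ccc(F)cc1-c1cc(Nc2ccc(Cl)cc2)nc(N)n1` gives 250 nM 
- compound 2 `Cc1ccc(Cl)cc1-c1cc(Nc2ccc(C(F)(F)F)cc2)nc(N)n1` gives 140 nM 

Among the compounds with values here, in a functional assay on K562 cells (Homo sapiens) for inhibition (a higher number here means a weaker inhibitor, a lower number a stronger inhibitor), compound 1 stands at 250 nM and compound 2 at 140 nM in a set of only two numbers, and these lie within the scatter of each other.

Compound 3 `Cc1ccc(Br)cc1-c1cc(Nc2ccc(Cl)cc2)nc(N)n1` has not yet been measured. Compared with compound 1 it carries a single change, bromo in place of fluoro on an aromatic carbon, para to a methyl group and meta to a large group (bromo in place of fluoro on an aromatic carbon). Within the data shown here, no measured pair isolates this change, so the data offer no direct step to borrow.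

A modest step in this assay is expected, toward a lower number if it moves at all, and it may well stay within the scatter. This expectation leans only on the closeness of compound 1 at 250 nM and compound 2 at 140 nM in this small set. The estimated move is a 1.5-fold lower number from compound 1 to compound 3 (0.17 log units; within the scatter) and remains tentative. Compound 3 is expected at 170 nM with an estimated range from 70 nM to 400 nM for now.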

Compound 3, half-maximal inhibitory concentration: 70 nM
The estimate for compound 3 lay 2.4-fold (0.39 log units) above the measured number, and the stated range covers the measured number.
By their numbers in this assay, from the lowest: compounds 3, 2 and 1 (each within the scatter of the next, the first and the last beyond it).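

In this assay, within the data shown here, the exchange of fluoro for bromo on an aromatic carbon, para to a methyl group and meta to a large group, gives the first step that isolates a single change (a 3.6-fold lower number from compound 1 to compound 3 (0.55 log units; beyond the scatter)). This position is thus not indifferent to which halogen it carries: one heavy atom replaces one heavy atom, the counts of hydrogen-bond donors and acceptors and the net charge stay the same, and the number still moves beyond the scatter. Nothing on hand gives a measured explanation for this step.

A single pair cannot show how the number at this carbon would respond to a methoxy group, an amine or a nitrile, so the reading rests on bromo and fluoro alone. As far as these compounds go, it also remains open whether the exchange of fluoro for bromo would give a step of similar size alongside the trifluoromethyl group of compound 2, in place of the chloro shared by compound 1 and compound 3.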